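Pyridin-3-yl for phenyl on the sulfonyl sulfur

The source may hold more compounds than are shown below. What is called first, only, known or untested is meant among the compounds shown, and "the series" means these compounds.

Among the measured compounds shown here, in a functional assay on NCI60 cells (Homo sapiens) for inhibition (on this read-out lower numbers stand for stronger inhibition of growth and higher numbers for weaker inhibition of growth), compound 1 `O=C1C=CC(O)(c2cc3ccccc3n2S(=O)(=O)c2ccccc2)C=C1` gives 39 nM and stands second highest of the three numbers so far, with compound 2 `O=C1C=CC(O)(c2cc3ccc(F)cc3n2S(=O)(=O)c2ccccc2)C=C1` at 16 nM on the lower side and compound 3 `CCOC(=O)Nc1ccc(S(=O)(=O)n2c(C3(O)C=CC(=O)C=C3)cc3ccccc32)cc1` at 190 nM on the higher side. Compound 4 `O=C1C=CC(O)(c2cc3ccccc3n2S(=O)(=O)c2cccnc2)C=C1` is not yet measured. Its difference from compound 1 is pyridin-3-yl in place of phenyl on a sulfonyl sulfur and amounts to pyridin-3-yl in place of phenyl on a sulfonyl sulfur.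

Two measured steps give the scale, though neither changes that group. Fluoro in place of hydrogen on an aromatic carbon gave a 2.4-fold lower number from compound 1 to compound 2 (0.39 log units; beyond the scatter) and (ethoxycarbonyl)amino in place of hydrogen on an aromatic carbon gave a 4.9-fold higher number from compound 1 to compound 3 (0.69 log units; beyond the scatter) as a modest move the other way. These steps set a rough size but no direction for the new change. The estimated step is a 1.4-fold higher number from compound 1 to compound 4 (0.15 log units; within the scatter) and no shift beyond the scatter is expected. Compound 4 is estimated at 55 nM with 20 nM to 150 nM as the expected range.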

Compound 4, concentration for 50% growth inhibition: 410 nM
Beside the measured number, compound 4's estimate is 7.5-fold (0.87 log units) below it; the measured number lies above the stated range.
By their numbers in this assay, from the lowest: compound 2; then compound 1; then compound 3; then compound 4.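

In this assay the group on the sulfonyl sulfur proves sensitive to a small edit: pyridin-3-yl in place of phenyl gives an 11-fold higher number from compound 1 to compound 4 (1.02 log units; beyond the scatter) while the count of heavy atoms stays the same, with one ring carbon exchanged for nitrogen and one hydrogen-bond acceptor added. This step is larger than the earlier change on that same ring, a 4.9-fold higher number from compound 1 to compound 3 (0.69 log units; beyond the scatter), even though that change added a whole (ethoxycarbonyl)amino group. Nothing available accounts for the size of this step.

The compounds shown leave open whether the step follows from having a ring nitrogen at all or from where that nitrogen stands in the ring. They also leave open how a methoxy group or an amine on the phenyl would compare with compound 1.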